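From 1,2,3,4-tetrahydroisoquinolin-2-yl to 4-methylpiperazin-1-yl

The compounds below may be only part of what the source reports. "The series", "measured", "known", "first", "only" and "open" are said of these compounds alone.

Values measured in a functional assay on A549 cells (Homo sapiens) for antiproliferative activity, read by MTT assay, with a stated time of 72 h; on this read-out higher numbers stand for weaker inhibition and lower numbers for stronger inhibition:
- compound 1 `COc1cc2c(Nc3ccc(C#N)cc3)ncnc2cc1OCCCN1CCCCC1CCO`: > 100000 nM (a limit)
- compound 2 `COc1cc2c(Nc3ccc(C#N)cc3)ncnc2cc1OCCCN1CCC(c2ccccc2)CC1`: 9500 nM
- compound 3 `COc1cc2c(Nc3ccc(C#N)cc3)ncnc2cc1OCCCN1CCc2ccccc2C1`: > 100000 nM (a limit)

Compound 3 has no exact value in this assay, only the limit > 100000 nM. This is the limit of > 100000 nM in this assay, at which 2 of the 3 values shown sit. Compound 4 `COc1cc2c(Nc3ccc(C#N)cc3)ncnc2cc1OCCCN1CCN(C)CC1` keeps the shared core and chain of compound 3 and differs only in the terminal group: 4-methylpiperazin-1-yl in place of 1,2,3,4-tetrahydroisoquinolin-2-yl on a saturated chain carbon, three bonds along the chain from an oxygen on an aromatic ring. The change lies on a saturated chain carbon, three bonds along the chain from an oxygen on an aromatic ring.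

Three measured steps at this place bear on it. Two are large, an at least 10-fold lower number from compound 1 to compound 2 (1.02 log units; beyond the scatter) and an at least 10-fold higher number from compound 2 to compound 3 (1.02 log units; beyond the scatter), and both involve the 4-phenylpiperidin-1-yl group of compound 2. The third, a step that the two limits leave unreadable from compound 1 to compound 3, cannot be sized. Compound 4 lacks that group, so it is expected to resemble compound 1 and compound 3 more than compound 2, which reaches 9500 nM. A report of the limit alone would therefore not be surprising.

The expected change is an at least 2.5-fold lower number from compound 3 to compound 4 (0.39 log units; beyond the scatter), a modest one at most. For compound 4 the estimated value is 40000 nM, with an expected range of 10000 nM to 100000 nM.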

Compound 4, half-maximal inhibitory concentration: 48800 nM
Beside the measured number, compound 4's estimate is 1.2-fold (0.09 log units) below it; the range from low to high includes it.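

In this assay, compound 4 gives this position a second exact value, so a terminal group other than 4-phenylpiperidin-1-yl can now be sized against that group, and the result is a 5.1-fold higher number from compound 2 to compound 4 (0.71 log units; beyond the scatter). The 4-methylpiperazin-1-yl group also separates from the two terminal groups whose compounds sit at the assay limit, with an at least 2.0-fold lower number from compound 3 to compound 4 (0.31 log units; beyond the scatter) and an at least 2.0-fold lower number from compound 1 to compound 4 (0.31 log units; beyond the scatter). A measurable value on a saturated chain carbon, three bonds along the chain from an oxygen on an aromatic ring, therefore does not require the 4-phenylpiperidin-1-yl group, although compound 2, which carries it, retains the lowest number among the four compounds.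

Going by these compounds, compound 1 and compound 3 are known only as limits, so the step between them cannot be read and the true size of their steps to compound 4 stays open: the limit of > 100000 nM in this assay, at which 2 of the 4 values shown sit. It also remains open how a morpholine, a pyrrolidine or a 4-benzylpiperidine at the end of this chain, or a longer chain carrying 4-phenylpiperidin-1-yl, would fall in this assay.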